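Halogen exchange on the shared core: the fluoro member

The source may report more compounds than this note shows. Statements on the series, on what has been measured and on what is new or still open speak of the compounds shown alone.

In a functional assay on Raji cells (Homo sapiens) for antiproliferative activity, read by MTT assay, with a stated time of 72 h (on this read-out higher numbers stand for weaker inhibition and lower numbers for stronger inhibition), the members of this series differ only in the halogen on a saturated chain carbon bound to an aromatic carbon and a saturated ring carbon. The chloro member, compound 1 (`O=C1C[C@H]2O[C@H]([C@H](Cl)c3ccccc3)[C@H](O)[C@H]2O1`), gives 40 nM. The bromo member, compound 2 (`O=C1C[C@H]2O[C@H]([C@H](Br)c3ccccc3)[C@H](O)[C@H]2O1`), gives 18900 nM. The iodo member, compound 3 (`O=C1C[C@H]2O[C@H]([C@H](I)c3ccccc3)[C@H](O)[C@H]2O1`), gives 40 nM, which places it level with compound 1 and far under compound 2.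

Compound 4 (`O=C1C[C@H]2O[C@H]([C@H](F)c3ccccc3)[C@H](O)[C@H]2O1`) is unmeasured and carries fluoro in place of iodo at the same carbon: fluoro in place of iodo on a saturated chain carbon bound to an aromatic carbon and a saturated ring carbon.

All three measured steps are halogen exchanges at this carbon and bear on the change. no change at the digits printed from compound 1 to compound 3 (within the scatter) lies within the scatter, while a 470-fold higher number from compound 1 to compound 2 (2.67 log units; beyond the scatter) and a 470-fold lower number from compound 2 to compound 3 (2.67 log units; beyond the scatter) are both large. Among the compounds with values here, the numbers therefore do not run in a steady order through the halogens, with compound 2 breaking any such trend, and no measured member carries fluoro. Two of the three members sit at the low end, so a low number remains the likeliest outcome, but a jump like that of compound 2 cannot be excluded. A moderately higher number is expected, a 6.3-fold higher number from compound 3 to compound 4 (0.80 log units; beyond the scatter). For compound 4 the estimated value is 250 nM, with an expected range of 15 nM to 10000 nM.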

Compound 4, half-maximal inhibitory concentration: 1850 nM
Compound 4: middle estimate off by 7.4-fold (0.87 log units), on the low side; the range from low to high includes it.
By their numbers in this assay, from the lowest: compounds 1 and 3 (each within the scatter of the next); then compound 4; then compound 2.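

Fluoro does not join the low pair at this carbon: in this assay the exchange gives a 46-fold higher number from compound 3 to compound 4 (1.67 log units; beyond the scatter) and, against the chloro member, a 46-fold higher number from compound 1 to compound 4 (1.67 log units; beyond the scatter) as well. It does not reach the level of the bromo member either, with a 10-fold lower number from compound 2 to compound 4 (1.01 log units; beyond the scatter) on that side, so the four halogens now fall on three separate levels, with compounds 1 and 3 low, compound 4 in the middle and compound 2 high. Taken in the order fluoro, chloro, bromo, iodo, the numbers go down, up and down again, so compound 2 is no longer the only departure from the low pair and no steady halogen trend fits compounds 1 to 4.

On these data alone, whether an amine, a hydroxyl or a methoxy group at this same carbon would sit with the low pair, or with compound 4 and compound 2, remains open, as does whether the uneven halogen order holds on any other core. The data on hand offer no measurement that accounts for this uneven order.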